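The source may hold more compounds than are shown below. What is called first, only, known or untested is meant among the compounds shown, and "the series" means these compounds.

Compound 1 `C[n+]1ccn(COCC[Si](C)(C)C)c1/C=N/O` is one of two compounds tested in a physicochemical assay for lipophilicity; a higher number here means a more lipophilic compound, a lower number a more polar compound. In this assay compound 1 gives -0.34, and compound 2 `C[n+]1ccn(CCCCOC(=O)c2ccccc2O)c1/C=N/O` gives -0.56; the two numbers lie within the scatter of each other, so neither stands apart. Compound 3 `C[n+]1ccn(COCC(C)(C)[N+](=O)[O-])c1/C=N/O` has not yet been measured. It differs from compound 1 in one place: a group of 6 heavy atoms (3 carbon, 1 nitrogen, 2 oxygen; no ring) in place of a group of 5 heavy atoms (4 carbon, 1 silicon; no ring), on a saturated chain carbon bound to an oxygen on a saturated carbon. Within the data shown here, no step between measured compounds covers such a change. A step from compound 1 to compound 3 of a number 0.96 log units lower from compound 1 to compound 3 (beyond the scatter) is expected in this assay, beyond the scatter and downward. Compound 3 is estimated at -1.3, within a range from -1.9 to -0.7.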

Compound 3, distribution coefficient: -1.96
Compound 3: middle estimate off by 0.66 log units, on the high side, and the stated range ends above it.
By their numbers in this assay, from the lowest: compound 3; then compounds 2 and 1 (each within the scatter of the next).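

In this assay, 1-methyl-1-nitroethyl in place of the group of 5 heavy atoms that holds the silicon gives a number 1.62 log units lower from compound 1 to compound 3 (beyond the scatter). Among these compounds, this is the first measured step at this position, and it shows that the number can move far with the group carried on this chain. No measurement at hand accounts for the size of this step.

On these data alone, how much of the step goes with the nitro group and how much with the loss of silicon stays open. So does where an all-carbon tert-butyl group or an amine in the same place would fall.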